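The source may report more compounds than this note shows. Statements on the series, on what has been measured and on what is new or still open speak of the compounds shown alone.

Compound 1 `COc1ccc(N2C(=O)NC3(CSC4=C3C(=O)c3ncccc3C4=O)C2=O)cc1` is one of three measured compounds that share a single core and differ only in the group carried on the outer six-membered ring. In a functional assay on CCRF-SB cells (Homo sapiens) for antiproliferative activity, read by MTT assay, with a stated time of 96 h (a lower number here means a stronger inhibitor, a higher number a weaker inhibitor), compound 1 gives 10 nM. Compound 2 `O=C1C2=C(C(=O)c3ncccc31)C1(CS2)NC(=O)N(c2ccccc2)C1=O` gives 30 nM, and compound 3 `CCc1ccc(N2C(=O)NC3(CSC4=C3C(=O)c3ncccc3C4=O)C2=O)cc1` gives 10 nM. On these numbers compound 1 stands level with compound 3, the two together the lowest of the three, and its furthest neighbour is compound 2, reached by the step of a 3.0-fold higher number from compound 1 to compound 2 (0.48 log units; beyond the scatter).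

Compound 4 `Cc1ccc(N2C(=O)NC3(CSC4=C3C(=O)c3ncccc3C4=O)C2=O)cc1` is not yet measured. It differs from compound 1 by methyl in place of methoxy on an aromatic carbon. Going by the values given here, two measured steps bear on this: a 3.0-fold higher number from compound 1 to compound 2 (0.48 log units; beyond the scatter), where hydrogen replaced methoxy, and no change at the digits printed from compound 1 to compound 3 (within the scatter), where ethyl replaced methoxy. Methyl is smaller than ethyl yet more than hydrogen, so the step of a 1.4-fold higher number from compound 1 to compound 4 (0.15 log units; within the scatter) is expected to be small, most likely within the scatter, with any drift toward a higher number. Compound 4 is therefore estimated at 14 nM, with a likely range from 6 nM to 35 nM.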

Compound 4, half-maximal inhibitory concentration: 20 nM
The estimate for compound 4 lay 1.4-fold (0.15 log units) below the measured number; low and high end bracket the measured number.
By their numbers in this assay, from the lowest: compounds 1, 3, 4 and 2 (each within the scatter of the next, the first and the last beyond it).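

In this assay, methyl at this place on the aromatic ring has no step beyond the scatter to any of the three earlier compounds: a 2.0-fold higher number from compound 1 to compound 4 (0.30 log units; within the scatter), a 2.0-fold higher number from compound 3 to compound 4 (0.30 log units; within the scatter) and a 1.5-fold lower number from compound 2 to compound 4 (0.18 log units; within the scatter). Going by these compounds alone, compound 4 therefore sits inside the one gap the earlier compounds showed, between compound 2, with hydrogen, and compound 1 and compound 3, and belongs clearly to neither side, so these four compounds do not split into two separate groups. Nothing shown here explains these small differences.

Going by these compounds, whether an amine, a carboxylic acid or a chain longer than ethyl at this place would move the number further remains open. So does whether any of these four groups would behave the same way elsewhere on the aromatic ring.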